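The source may hold more compounds than are shown below. What is called first, only, known or untested is meant among the compounds shown, and "the series" means these compounds.

All the compounds here share one core and differ in what sits on an aromatic nitrogen. In a functional assay on Bel-7402 cells (Homo sapiens) for antiproliferative activity, read by MTT assay, with a stated time of 72 h (on this read-out lower numbers stand for stronger inhibition and higher numbers for weaker inhibition), compound 1 `C=C1C(=O)O[C@H]2[C@H]1CC/C(COC(=O)Cn1cc(F)c(=O)[nH]c1=O)=C\CC[C@@]1(C)O[C@@H]21`, with hydrogen at that spot, gives > 20000 nM, which is a limit of the assay and not a number. Compound 2 `C=C1C(=O)O[C@H]2[C@H]1CC/C(COC(=O)Cn1cc(F)c(=O)n(Cc3ccc(Cl)cc3)c1=O)=C\CC[C@@]1(C)O[C@@H]21` gives 2560 nM. Compound 3 `C=C1C(=O)O[C@H]2[C@H]1CC/C(COC(=O)Cn1cc(F)c(=O)n(Cc3cc(F)ccc3F)c1=O)=C\CC[C@@]1(C)O[C@@H]21` gives 3060 nM. The measured step between these two benzyl compounds is a 1.2-fold higher number from compound 2 to compound 3 (0.08 log units; within the scatter), so compound 3 stands level with compound 2.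

Compound 4 `C=C1C(=O)O[C@H]2[C@H]1CC/C(COC(=O)Cn1cc(F)c(=O)n(CCC)c1=O)=C\CC[C@@]1(C)O[C@@H]21` differs from compound 3 as follows: ethyl in place of 2,5-difluorophenyl on a saturated chain carbon bound to an aromatic nitrogen. In words, 2,5-difluorobenzyl gives way to propyl. Two measured steps put a benzyl group on that nitrogen: an at least 7.8-fold lower number from compound 1 to compound 2 (0.89 log units; beyond the scatter) and an at least 6.5-fold lower number from compound 1 to compound 3 (0.81 log units; beyond the scatter). Neither shows whether a chain without a ring does as well. Part of that gain is expected to remain with propyl, along with a small loss, in the direction of a higher number. The expected step is a 1.5-fold higher number from compound 3 to compound 4 (0.17 log units; within the scatter). For compound 4 the estimated value is 4500 nM, with an expected range from 1800 nM to 15000 nM.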

Compound 4, half-maximal inhibitory concentration: 8580 nM
Compound 4: the middle estimate sits 1.9-fold (0.28 log units) below what was measured; the range from low to high includes it.
By their numbers in this assay, from the lowest: compounds 2 and 3 (each within the scatter of the next); then compound 4. At a limit, above all of these: compound 1.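

Propyl on the aromatic nitrogen shows that a chain with no ring keeps part of the gain in this assay: an at least 2.3-fold lower number from compound 1 to compound 4 (0.36 log units; beyond the scatter). That step gives only a minimum size, because compound 1 stands at a limit of the assay: the limit of > 20000 nM in this assay, at which 1 of the 4 values shown sits. The ring-bearing groups still do better than propyl, with a 2.8-fold higher number from compound 3 to compound 4 (0.45 log units; beyond the scatter) and a 3.4-fold higher number from compound 2 to compound 4 (0.53 log units; beyond the scatter), so on these compounds a chain alone does not match either benzyl group.

Going by these compounds, what remains open is whether the ring itself matters or simply the extra carbon and halogen atoms, and a longer chain such as hexyl, or a plain benzyl group with no halogen, would help to separate these. How an amine or a carboxylic acid at the end of such a chain would behave at this nitrogen is also unknown from these compounds.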